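The compounds below may be only part of what the source reports. "The series", "measured", "known", "first", "only" and "open" are said of these compounds alone.

The measured compounds in a functional assay on the whole organism with Mus musculus as the target; a lower number here means a less potent compound, a higher number a more potent compound, by a factor of ten per unit of this negative logarithm:
Compound 1, `Cc1cc(C)c(C(=O)OC2CCN(C)CC2)cc1C`, gives 1.17.
Compound 2, `CN1CCC(OC(=O)c2ccccc2Cc2ccccc2)CC1`, gives 1.28.
Compound 3, `CN1CCC(OC(=O)c2ccc(C#N)cc2)CC1`, gives 1.65.

Compound 2 holds the second highest of these three numbers. Its nearest neighbour is compound 1, whose number lies within the scatter of that of compound 2, so the two cannot be told apart. Compound 3 lies furthest away, with a higher number that is beyond the scatter.

The unmeasured compound 4, `CN1CCC(OC(=O)c2ccccc2F)CC1`, differs from compound 2 in one place: fluoro in place of benzyl on an aromatic carbon. Among the compounds with values here, no measured pair shows a change of this kind, so there is no direct guide to how large a step to expect, and the three measured compounds differ from one another in several places at once. Any expectation here is therefore tentative. For compound 4 a step from compound 2 of about a number 0.22 log units higher from compound 2 to compound 4 (within the scatter) is expected, upward and only modestly beyond the scatter. The estimate for compound 4 in this assay is 1.5, expected to lie between 1 and 2.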

Compound 4, logarithm of the reciprocal of the active concentration, log(1/C): 1.41
Beside the measured number, compound 4's estimate is 0.09 log units above it; the measured number falls inside the stated range.
By their numbers in this assay, from the lowest: compounds 1, 2, 4 and 3 (each within the scatter of the next, the first and the last beyond it).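

In this assay putting fluoro in place of benzyl on this aromatic carbon gives a number 0.13 log units higher from compound 2 to compound 4 (within the scatter) and so leaves the two compounds indistinguishable. Within the data shown here, this is the first pair here that differs in one place only, and it shows that a single fluorine atom and a benzyl group, with its seven carbons and aromatic ring, can occupy this position without a difference that this measurement can resolve. No measurement of any other property is available to account for this result. From the compounds shown here alone, it remains open whether an amine or a carboxylic acid on this same aromatic carbon would also stay within the scatter of compound 2. Whether fluoro would give a similar result on another core also remains unanswered.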